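Series notes: azetidinyl replacement on the benzylic position

This account rests on a few compounds, and the source may have more. Where it says the series, first, only, none or still open, it means among the compounds named here.

Among the measured compounds shown here, in an assay for inhibition of Tryptophan 2,3-dioxygenase (Homo sapiens), with stated times of 10 min and 60 min (on this read-out higher numbers stand for weaker inhibition and lower numbers for stronger inhibition), compound 1 `Nc1cccc(CNc2cc(C(F)(F)F)cc3[nH]ncc23)c1` gives 2510 nM, the second highest of the three numbers so far. Compound 2 `O=C(O)c1cccc(CNc2cc(C(F)(F)F)cc3[nH]ncc23)c1` gives 1690 nM in this assay; the step of a 1.5-fold lower number from compound 1 to compound 2 (0.17 log units; within the scatter) is within the scatter. Compound 3 `CNC(=O)c1cccc(CNc2cc(C(F)(F)F)cc3[nH]ncc23)c1` gives 4870 nM in this assay; the step of a 1.9-fold higher number from compound 1 to compound 3 (0.29 log units; within the scatter) is also within the scatter, and only a 2.9-fold higher number from compound 2 to compound 3 (0.46 log units; beyond the scatter) reaches beyond it, as a modest shift.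

Compound 4 `FC(F)(F)c1cc(NCC2CNC2)c2cn[nH]c2c1` has not yet been measured in this assay. It differs from compound 1 in one place: azetidin-3-yl in place of 3-aminophenyl on a saturated chain carbon bound to a nitrogen on an aromatic ring. For the measured compounds named here, none of the measured steps touches this position; all three concern the group on the phenyl ring, which itself leaves in compound 4, so they give no direct guide. Those steps were small, and in the absence of a relevant precedent the expectation is for no shift beyond the scatter, with the range widened to reflect the lack of guidance. The expected step is a 1.4-fold higher number from compound 1 to compound 4 (0.14 log units; within the scatter). Compound 4 is therefore estimated at 3500 nM in this assay, with a range from 1000 nM to 12000 nM.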

Compound 4, half-maximal inhibitory concentration: > 100000 nM
Compound 4 was reported as a limit; the forecaster's own chance of this, stated with the estimate: 15%; middle value at least 28-fold (1.45 log units) from the limit.
By their numbers in this assay, from the lowest: compounds 2, 1 and 3 (each within the scatter of the next, the first and the last beyond it). At a limit, above all of these: compound 4.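

Azetidin-3-yl in place of 3-aminophenyl on a saturated chain carbon bound to a nitrogen on an aromatic ring gives an at least 39-fold higher number from compound 1 to compound 4 (1.60 log units; beyond the scatter), the only large step among those shown. The earlier steps shown here changed only the group on the phenyl ring and moved the numbers modestly at most, whereas replacing the whole aromatic ring at this position costs far more in this assay. For compound 4 the result is a limit and not a number: the limit of > 100000 nM in this assay, at which 1 of the 4 values shown sits.

The compounds shown do not separate the departure of the six-membered aromatic ring from the arrival of the four-membered non-aromatic ring. A plain phenyl, a pyridinyl or a cyclohexyl group on the same chain carbon would help to tell these two apart, as would a piperidin-4-yl ring.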